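The compounds below may be only part of what the source reports. "The series", "measured", "known", "first", "only" and "open" are said of these compounds alone.

In a functional assay on MCF7 cells (Homo sapiens) for cytotoxicity, read by MTT assay, with a stated time of 72 h (on this read-out lower numbers stand for stronger inhibition and higher numbers for weaker inhibition), compound 2 `Cc1cc(S(=O)(=O)/N=C(\N)n2nccc2-c2ccccc2)c(SCc2cccc3ccccc23)cc1Cl` gives 58000 nM. In this assay compound 1 `Cc1cccc(CSc2cc(Cl)c(C)cc2S(=O)(=O)/N=C(\N)n2nccc2-c2ccccc2)c1` gives 47000 nM, and the two numbers lie within the scatter of each other, as the step of a 1.2-fold higher number from compound 1 to compound 2 (0.09 log units; within the scatter) shows. Compound 3 `Cc1cc(S(=O)(=O)/N=C(\N)n2nccc2-c2ccccc2)c(SCc2ccccc2C)cc1Cl` differs from compound 2 by 2-methylphenyl in place of naphthalen-1-yl on a saturated chain carbon bound to a sulfur. For the measured compounds named here, the one step at this place, which exchanged one aromatic group for another, stayed within the scatter, so no shift beyond the scatter is expected here either. Compound 3 is therefore estimated at 50000 nM, with a range from 25000 nM to 100000 nM. This amounts to an expected step of a 1.2-fold lower number from compound 2 to compound 3 (0.06 log units; within the scatter).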

Compound 3, half-maximal inhibitory concentration: 23000 nM
For compound 3 the middle estimate is 2.2-fold (0.34 log units) above the measured one, and the stated range ends above it.
By their numbers in this assay, from the lowest: compound 3; then compounds 1 and 2 (each within the scatter of the next).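

In this assay this position proves able to respond to the aromatic group it carries, with a 2.5-fold lower number from compound 2 to compound 3 (0.40 log units; beyond the scatter) and a 2.0-fold lower number from compound 1 to compound 3 (0.31 log units; beyond the scatter) both modest but beyond the scatter. Moving the methyl group from 3-methylphenyl to 2-methylphenyl is enough to shift the number, so the placement of one small group matters here, not only the choice of aromatic group. No measurement shown explains this shift. On these data alone, it remains open how an amine or a carboxylic acid on the phenyl ring would compare. A longer chain in place of the saturated chain carbon bound to a sulfur is also untested among the compounds shown.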